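Trifluoromethyl for Methyl on a Weak Prostacyclin Antagonist

The source may hold more compounds than are shown below. What is called first, only, known or untested is meant among the compounds shown, and "the series" means these compounds.

Of the compounds shown here, two have been tested so far in a functional assay on C6 cells for antagonist activity at prostacyclin receptor (Homo sapiens), read by TR-FRET and cAMP accumulation, with stated times of 10 min and 40 min; on this read-out lower numbers stand for stronger inhibition and higher numbers for weaker inhibition. Compound 1, with the structure `Cc1cc2ccccc2n1CCNC(=O)/C=C/c1ccc(OCCO)c(OCCO)c1`, gives 1570 nM in this assay. Compound 2, with the structure `COc1cc(/C=C/C(=O)NCCn2c(C)cc3ccccc32)cc(OC)c1OCCO`, gives 85000 nM in this assay, the higher of the two numbers and therefore the weaker of the pair, and its gap to compound 1 lies well beyond the usual scatter of repeated measurements.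

Compound 3, with the structure `COc1cc(/C=C/C(=O)NCCn2c(C(F)(F)F)cc3ccccc32)cc(OC)c1OCCO`, has not yet been measured. It differs from compound 2 in one place: trifluoromethyl in place of methyl on an aromatic carbon. Among the measured compounds shown here, no pair of measured compounds shows this change, so there is no observed step to lean on, and the expectation for compound 3 rests on compound 2 alone. A step of this kind is expected to move the number only modestly, if at all, so the estimated step from compound 2 to compound 3 in this assay is a 1.4-fold lower number from compound 2 to compound 3 (0.15 log units; within the scatter). Compound 3 is therefore expected to give about 60000 nM in this assay, with a range from 15000 nM to 200000 nM.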

Compound 3, antagonist equilibrium constant: 95900 nM
Estimate against measurement, compound 3: 1.6-fold (0.20 log units) below; measured number inside the range.
By their numbers in this assay, from the lowest: compound 1; then compounds 2 and 3 (each within the scatter of the next).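

In this assay, placing trifluoromethyl in place of methyl on the aromatic carbon next to the ring nitrogen gives a 1.1-fold higher number from compound 2 to compound 3 (0.05 log units; within the scatter), so this single change leaves compound 2 and compound 3 indistinguishable. Among the compounds shown here, this is the first direct reading at this position, and it shows that the exchange of methyl for trifluoromethyl, a group with more heavy atoms, neither measurably improves nor measurably worsens the number on this core, with compound 3 at 95900 nM still far from a strong result. Nothing measured here explains why the number stays put, and this single pair cannot show whether the position is generally insensitive to change.

It remains open whether a group of a different kind on this same carbon, such as an amine, a carboxylic acid or a longer chain, would move the number beyond the scatter, since methyl and trifluoromethyl are the only groups shown there. Going by these compounds, it is also open whether the same exchange would behave the same way on the core of compound 1, which gives 1570 nM and would offer a stronger starting point for reading such a step.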